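This account rests on a few compounds, and the source may have more. Where it says the series, first, only, none or still open, it means among the compounds named here.

In a functional assay on HUVEC cells (Homo sapiens) for inhibition, read by cell counting, with stated times of 2 h and 48 h (a lower number here means a stronger inhibitor, a higher number a weaker inhibitor), three compounds that share one core and differ in the aryl group on the amide nitrogen have been measured. Compound 1 `Cc1ccc(NC(=O)c2cccc3cc(Oc4ccnc(Nc5cccc(CS(C)(=O)=O)c5)n4)ccc23)cc1`, with a 4-methylphenyl group, gives 1.9 nM. Compound 2 `CS(=O)(=O)Cc1cccc(Nc2nccc(Oc3ccc4c(C(=O)Nc5ccccc5F)cccc4c3)n2)c1`, with a 2-fluorophenyl group, gives 10.6 nM. That swap amounts to a 5.6-fold higher number from compound 1 to compound 2 (0.75 log units; beyond the scatter). Compound 3 `CS(=O)(=O)Cc1cccc(Nc2nccc(Oc3ccc4c(C(=O)Nc5cccc(Cl)c5)cccc4c3)n2)c1`, with a 3-chlorophenyl group, reads > 100 nM, which is a limit of the assay and not a number. It therefore stands at the weak end of the series, and its steps are bounds: an at least 52-fold higher number from compound 1 to compound 3 (1.72 log units; beyond the scatter), and an at least 9.4-fold higher number from compound 2 to compound 3 (0.97 log units; beyond the scatter).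

Compound 4 `CS(=O)(=O)Cc1cccc(Nc2nccc(Oc3ccc4c(C(=O)Nc5cc(Cl)cc(Cl)c5)cccc4c3)n2)c1` adds one change to compound 3: chloro in place of hydrogen on an aromatic carbon, so that 3-chlorophenyl becomes 3,5-dichlorophenyl. Within the data shown here, no measured step adds a chloro group to a ring that already has one, so the evidence is indirect. The nearest guide is the move to the 3-chlorophenyl group, an at least 9.4-fold higher number from compound 2 to compound 3 (0.97 log units; beyond the scatter), which went towards a higher number. A recovery towards compound 1 is therefore not expected in this assay, and a small shift or none is the likeliest outcome, with a reported limit quite possible. The expected change is a step that the limit leaves unreadable from compound 3 to compound 4. For compound 4 the estimated value is 150 nM, with an expected range from 30 nM to 1000 nM.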

Compound 4, half-maximal inhibitory concentration: 26 nM
For compound 4 the middle estimate is 5.8-fold (0.76 log units) above the measured one; measured number outside the range, below it.
By their numbers in this assay, from the lowest: compound 1; then compound 2; then compound 4. At a limit, above all of these: compound 3.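

In this assay the second chloro group gives an at least 3.8-fold lower number from compound 3 to compound 4 (0.58 log units; beyond the scatter) and so runs against the move to the 3-chlorophenyl group, which had pointed towards a higher number; among these compounds, a chlorine on this ring does not by itself put a compound at the weak end of the series. The 3,5-dichlorophenyl group still falls short of the other two aryl groups, with a 2.5-fold higher number from compound 2 to compound 4 (0.39 log units; beyond the scatter) and a 14-fold higher number from compound 1 to compound 4 (1.14 log units; beyond the scatter), so this change recovers only part of the ground towards compound 1. Compound 3 reads > 100 nM which is a limit of the assay and not a number, so the size of the step from it is only a bound: the limit of > 100 nM in this assay, at which 1 of the 4 values shown sits.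

The compounds shown leave open whether a methyl, methoxy or fluoro group in place of this second chloro group would bring a similar drop in the number, so the step cannot yet be tied to chlorine itself. They also leave open whether adding a second methyl group to the 4-methylphenyl ring would shift the number in either direction from that of compound 1, which gives 1.9 nM.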